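Capping the Phenol: From Compound 3 to Compound 4

The compounds below may be only part of what the source reports. "The series", "measured", "known", "first", "only" and "open" are said of these compounds alone.

Three compounds sharing one core have been measured:
compound 1 `COc1ccc(-c2nc3cc(F)ccc3s2)cc1F` gives 20600 nM
compound 2 `COc1ccc(-c2nc3cc(F)ccc3s2)cc1Br` gives 6700 nM
compound 3 `COc1ccc(-c2nc3cc(F)ccc3s2)cc1O` gives 18400 nM

All three were tested in a functional assay on KM12 cells (Homo sapiens) for antiproliferative activity; a higher number here means a weaker inhibitor of growth, a lower number a stronger inhibitor of growth. Compound 3 holds the second highest of the three numbers: its value and that of compound 1 lie within the usual scatter, as the step of a 1.1-fold lower number from compound 1 to compound 3 (0.05 log units; within the scatter) shows, while the step of a 2.7-fold higher number from compound 2 to compound 3 (0.44 log units; beyond the scatter) is a modest one beyond the scatter. Going by the values given here, the only other step, a 3.1-fold lower number from compound 1 to compound 2 (0.49 log units; beyond the scatter), is likewise modest.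

Compound 4 `COc1ccc(-c2nc3cc(F)ccc3s2)cc1OC` differs from compound 3 by methyl in place of hydrogen on an oxygen on an aromatic ring. Among the compounds with values here, none of the measured steps concerns a change on an oxygen; each swaps one group for another on the aromatic carbon, and their sizes are all modest. Nothing here points to a step beyond the scatter in this assay in either direction, so compound 4 is expected to sit close to compound 3, a step of a 1.2-fold lower number from compound 3 to compound 4 (0.06 log units; within the scatter) being the estimate. Compound 4 is therefore estimated at 16000 nM, within a range of 6000 nM to 45000 nM.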

Compound 4, concentration for 50% growth inhibition: 290 nM
Estimate against measurement, compound 4: 55-fold (1.74 log units) above; measured number below the stated range.
By their numbers in this assay, from the lowest: compound 4; then compound 2; then compounds 3 and 1 (each within the scatter of the next).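

In this assay putting methyl on the hydroxy group gives by far the biggest change so far (a 63-fold lower number from compound 3 to compound 4 (1.80 log units; beyond the scatter)). The earlier swaps among fluoro, bromo and hydroxy on the aromatic carbon gave no hint that this position could respond so strongly. Methoxy also stands well apart from both halogens (a 23-fold lower number from compound 2 to compound 4 (1.36 log units; beyond the scatter); a 71-fold lower number from compound 1 to compound 4 (1.85 log units; beyond the scatter)), so among these four compounds, it is specifically methoxy at this place that goes with strong growth inhibition, not just any group other than hydroxy.

No supporting information is available to explain the size of this step. Going by these compounds, it also remains open whether a longer chain on the same oxygen, such as ethoxy, or an amine in place of methoxy would hold this level of activity.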